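Notes on the step from compound 3 to compound 4

The source may hold more compounds than are shown below. What is called first, only, known or untested is meant among the compounds shown, and "the series" means these compounds.

Compound 3 `COc1cccc(-c2cc(-c3ccccc3-c3ccccc3)n[nH]2)c1` gives 7500 nM in a functional assay on AGS cells (Homo sapiens) for inhibition, read by MTT assay, with a stated time of 48 h; on this read-out higher numbers stand for weaker inhibition of growth and lower numbers for stronger inhibition of growth. Among the three measured members it holds the second highest number. Compound 1 `O=[N+]([O-])c1cccc(-c2cc(-c3ccccc3)n[nH]2)c1` gives 11400 nM, a value within the scatter of compound 3, so no order between the two can be read. For the measured compounds named here, compound 2 `COc1ccc(-c2cc(-c3ccccc3-c3ccccc3)n[nH]2)cc1` gives 790 nM, and the one measured single-place step, a 9.5-fold higher number from compound 2 to compound 3 (0.98 log units; beyond the scatter), lies beyond the scatter.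

Compound 4 `Oc1ccccc1-c1cc(-c2ccccc2-c2ccccc2)n[nH]1` is not yet measured. It differs from compound 3 in one place: 2-hydroxyphenyl in place of 3-methoxyphenyl on an aromatic carbon. Going by the values given here, no measured step bears directly on this change. Among the compounds with values here, the only single-place step concerns a swap of 3-methoxyphenyl for 4-methoxyphenyl, not a hydroxyl, and compound 1 differs from the others in more than one place, so its value offers no clean comparison. The expected step is therefore a 1.3-fold lower number from compound 3 to compound 4 (0.10 log units; within the scatter), none beyond the scatter, with a wide range. Compound 4 is estimated at 6000 nM in this assay, between 1500 nM and 25000 nM.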

Compound 4, concentration for 50% growth inhibition: 7500 nM
For compound 4 the middle estimate is 1.3-fold (0.10 log units) below the measured one, and the stated range covers the measured number.
By their numbers in this assay, from the lowest: compound 2; then compounds 3, 4 and 1 (each within the scatter of the next).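

In this assay there is no change at the digits printed from compound 3 to compound 4 (within the scatter), so at this carbon of the shared core, 2-hydroxyphenyl and 3-methoxyphenyl cannot be told apart, although the entering group carries a hydrogen-bond donor and the leaving group carries none. Against 4-methoxyphenyl there is a 9.5-fold higher number from compound 2 to compound 4 (0.98 log units; beyond the scatter), so compound 2 now stands apart from two different replacements at this place rather than one. Nothing at hand bears on the reason for this result.

The step from compound 3 to compound 4 alters the oxygen group and its place on the phenyl ring together, so the two changes cannot be read separately. Also open, going by these compounds, is whether an amine or a carboxylic acid on this phenyl ring would give a number apart from those of compound 3 and compound 4.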